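Extending a quinoxaline methyl into a pyridinyl vinyl arm

A few compounds are considered here, and "the series" means these few. Any claim that something is new, unique, unknown or untested is made for them only; others in the source may bear on it.

The series is tested in a functional assay on PC-3 cells (Homo sapiens) for inhibition, read by MTT assay, with a stated time of 24 h; on this read-out lower numbers stand for stronger inhibition and higher numbers for weaker inhibition. Compound 2 `Cc1ccc(NC(=O)COc2nc3ccccc3nc2C)cc1` gives > 100000 nM there, which is a limit of the assay and not a number. Compound 1 `O=C(Cn1c(=O)c(/C=C\c2ccncc2)nc2ccccc21)Nc1ccccc1`, which already carries the pyridin-4-yl ethenyl arm on a different core, likewise gives > 100000 nM, again a limit. Compound 3 `Cc1nc2ccccc2nc1OCC(=O)Nc1ccc(Cl)cc1` gives 68100 nM in this assay. Going by the values given here, the one measured step, an at least 1.4-fold lower number from compound 2 to compound 3 (0.16 log units; that floor lies within the scatter), is too small to read, since it starts from the limit at which two of the three values sit (the limit of > 100000 nM in this assay, at which 2 of the 3 values shown sit).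

Compound 4 `Cc1ccc(NC(=O)COc2nc3ccccc3nc2/C=C\c2ccncc2)cc1` arises from compound 2 by 2-(pyridin-4-yl)ethenyl in place of methyl on an aromatic carbon. Among the compounds with values here, no measured step bears on this exchange directly; the only evidence is that compound 1, bearing the same arm, sits at the limit. He therefore expects compound 4 to remain weak, with no step beyond the scatter, namely an at least 1.1-fold lower number from compound 2 to compound 4 (0.04 log units; that floor lies within the scatter). His estimate for compound 4 is 90000 nM, within 30000 nM to 300000 nM, with a fair chance that this assay again reports only a limit.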

Compound 4, half-maximal inhibitory concentration: > 100000 nM
Compound 4: no number, only a limit; the forecaster's own chance of this, stated with the estimate: 60%; middle value at least 1.1-fold (0.04 log units) from the limit.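

In this assay compound 4 gives > 100000 nM, which is a limit and not a number. Going by these compounds alone, with compound 2 also at a limit, no step from compound 2 to compound 4 can be read: the limit of > 100000 nM in this assay, at which 3 of the 4 values shown sit. The compounds shown leave open whether 2-(pyridin-4-yl)ethenyl in place of methyl changes inhibition at all.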